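The source may hold more compounds than are shown below. What is called first, only, known or untested is meant among the compounds shown, and "the series" means these compounds.

Measured compounds:
- compound 1, `CCCS(=O)(=O)Nc1cccc2c1CCC2c1ncc[nH]1`, 54% in a functional assay on CHO cells for agonist activity at Alpha-1A adrenergic receptor (Homo sapiens), read by FLIPR and calcium flux; on this read-out lower numbers stand for smaller maximal responses and higher numbers for larger maximal responses
- compound 2, `c1cc(-c2cn[nH]c2)c2c(c1)C(c1ncc[nH]1)CC2`, 84%
- compound 3, `Cc1n[nH]cc1-c1cccc2c1CCC2c1ncc[nH]1`, 91%

Compound 3 has the highest of the three numbers in this assay; compound 2 lies within the scatter of it, while compound 1 is well below, as seen in a number 37 percentage points higher from compound 1 to compound 3 (beyond the scatter) and a number 30 percentage points higher from compound 1 to compound 2 (beyond the scatter). Compound 4, `Cn1nccc1-c1cccc2c1CCC2c1ncc[nH]1`, is not yet measured. It differs from compound 3 by 1-methyl-1H-pyrazol-5-yl in place of 3-methyl-1H-pyrazol-4-yl on an aromatic carbon. The measured steps bear on this only indirectly: both pyrazolyl groups gave a markedly larger maximal response than the (propylsulfonyl)amino group, and the step of a number 7 percentage points higher from compound 2 to compound 3 (within the scatter) shows that methyl in place of hydrogen on an aromatic carbon changed little. Within the data shown here, no measured pair covers a shift of the attachment point or the loss of the hydrogen-bond donor. The expectation is therefore that compound 4 stays in the range of the two pyrazolyl compounds, with a step of a number 9 percentage points lower from compound 3 to compound 4 (within the scatter) that is small, possibly slightly downward, and likely within the scatter. Compound 4 is estimated at 82%, range 62% to 98%.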

Compound 4, largest response reached (Emax), in percent of the reference or control that the assay uses: 58%
Compound 4: middle estimate off by 24 percentage points, on the high side; the measured number lies below the stated range.
By their numbers in this assay, from the lowest: compounds 1 and 4 (each within the scatter of the next); then compounds 2 and 3 (each within the scatter of the next).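

In this assay, a pyrazolyl group on this aromatic carbon does not by itself give the larger maximal response: 1-methyl-1H-pyrazol-5-yl gives a number 33 percentage points lower from compound 3 to compound 4 (beyond the scatter) and a number 26 percentage points lower from compound 2 to compound 4 (beyond the scatter) despite having the same ring type and heavy-atom count as the group it replaces in compound 3. Compared with (propylsulfonyl)amino, the same group gives a number 4 percentage points higher from compound 1 to compound 4 (within the scatter) and so shows that the earlier gain does not extend to every pyrazolyl group. The data give no cause for the difference between these isomeric groups.

Still open, from the compounds shown here alone, is whether the attachment point or the hydrogen-bond donor count tracks the response, since both differ in compound 4. A 1-methyl-1H-pyrazol-4-yl group and an unmethylated 1H-pyrazol-5-yl group on the shared core would separate these two changes.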